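Cyclopropyl for ethyl on the oxadiazole of compound 3

This account rests on a few compounds, and the source may have more. Where it says the series, first, only, none or still open, it means among the compounds named here.

Measured compounds and their values in an assay on brain for displacement of a labelled ligand from D(3) dopamine receptor (Rattus norvegicus); on this read-out higher numbers stand for weaker inhibition and lower numbers for stronger inhibition:
compound 1 `CCCN(CC[C@H]1CC[C@H](NC(=O)c2ccc(-n3cccn3)cc2)CC1)[C@H]1CCc2nc(N)sc2C1`: 3 nM
compound 2 `CCCN(CC[C@H]1CC[C@H](NC(=O)c2ccc(-c3noc(C)n3)cc2)CC1)[C@H]1CCc2nc(N)sc2C1`: 1.3 nM
compound 3 `CCCN(CC[C@H]1CC[C@H](NC(=O)c2ccc(-c3noc(CC)n3)cc2)CC1)[C@H]1CCc2nc(N)sc2C1`: 2.1 nM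

Compound 3 stands second highest of the three numbers in this assay; compound 1 lies nearest, and compound 2 furthest, both within the scatter of compound 3. Compound 4 `CCCN(CC[C@H]1CC[C@H](NC(=O)c2ccc(-c3noc(C4CC4)n3)cc2)CC1)[C@H]1CCc2nc(N)sc2C1` differs from compound 3 in one place: cyclopropyl in place of ethyl on an aromatic carbon. The measured steps that touch this position are a 1.6-fold higher number from compound 2 to compound 3 (0.21 log units; within the scatter), which grew the substituent on the same carbon by one carbon and stayed within the scatter, while a 2.3-fold lower number from compound 1 to compound 2 (0.36 log units; beyond the scatter) and a 1.4-fold lower number from compound 1 to compound 3 (0.15 log units; within the scatter) changed the whole five-membered ring. Growth at this carbon has so far done little, so for compound 4 the account expects a step of a 1.1-fold lower number from compound 3 to compound 4 (0.02 log units; within the scatter) that stays within the scatter, in no clear direction. Compound 4 is therefore estimated at 2 nM in this assay, with a range from 0.8 nM to 5 nM.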

Compound 4, inhibition constant: 3.5 nM
Compound 4: the middle estimate sits 1.8-fold (0.24 log units) below what was measured; low and high end bracket the measured number.
By their numbers in this assay, from the lowest: compounds 2, 3, 1 and 4 (each within the scatter of the next, the first and the last beyond it).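

Closing the ethyl into cyclopropyl on this carbon of the oxadiazole leaves the read-out in this assay within the scatter (a 1.7-fold higher number from compound 3 to compound 4 (0.22 log units; within the scatter)), so the ring is accepted here as readily as the open chain. Measured against the methyl, however, the cyclopropyl gives the first step at this carbon that lies beyond the scatter (a 2.7-fold higher number from compound 2 to compound 4 (0.43 log units; beyond the scatter)), a modest one towards weaker inhibition that the ethyl alone had not shown. The edge that the methyl oxadiazole held over the pyrazole is also absent with cyclopropyl, as that exchange stays within the scatter (a 1.2-fold higher number from compound 1 to compound 4 (0.07 log units; within the scatter)). The compounds shown leave open how a hydrogen, an amine or a tert-butyl on this carbon would read. No measurement at hand says why the cyclopropyl reads as it does.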